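Swapping the phenyl group in a level series

The source may hold more compounds than are shown below. What is called first, only, known or untested is meant among the compounds shown, and "the series" means these compounds.

Compound 1 (`O=C(/C=C/c1cccc(Cl)c1Cl)Nc1cc2c(Nc3ccc(F)c(Cl)c3)ncnc2cc1O[C@H]1CCOC1`) gives 30100 nM
Compound 2 (`O=C(/C=C/c1cc(Br)c(O)c(Br)c1)Nc1cc2c(Nc3ccc(F)c(Cl)c3)ncnc2cc1O[C@H]1CCOC1`) gives 30600 nM
Compound 3 (`O=C(/C=C/c1ccc(F)cc1Cl)Nc1cc2c(Nc3ccc(F)c(Cl)c3)ncnc2cc1O[C@H]1CCOC1`) gives 26200 nM

All three values from a functional assay on MCF7 cells (Homo sapiens) for cytotoxicity, read by MTT assay, with a stated time of 72 h (a higher number here means a weaker inhibitor, a lower number a stronger inhibitor), stand level, and compound 3 sits with the other two (a 1.1-fold lower number from compound 1 to compound 3 (0.06 log units; within the scatter); a 1.2-fold lower number from compound 2 to compound 3 (0.07 log units; within the scatter)). Compound 4 (`COc1ccc(/C=C/C(=O)Nc2cc3c(Nc4ccc(F)c(Cl)c4)ncnc3cc2O[C@H]2CCOC2)cc1`) carries 4-methoxyphenyl in place of 2-chloro-4-fluorophenyl on a double-bonded chain carbon bound to a double-bonded chain carbon. Earlier swaps at this same place, including the one left to mention (a 1.0-fold higher number from compound 1 to compound 2 (0.01 log units; within the scatter)), all stayed within the scatter. Within the data shown here, no measured step tests 4-methoxyphenyl itself, so the range stays wide. In this assay the expected step is therefore a 1.1-fold higher number from compound 3 to compound 4 (0.03 log units; within the scatter). Compound 4 is estimated at 28000 nM (expected range 14000 nM to 50000 nM).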

Compound 4, half-maximal inhibitory concentration: 5070 nM
The estimate for compound 4 lay 5.5-fold (0.74 log units) above the measured number; the whole stated range lies above it.
By their numbers in this assay, from the lowest: compound 4; then compounds 3, 1 and 2 (each within the scatter of the next).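

This position is less flat than the first three compounds suggested: in this assay the change to 4-methoxyphenyl gives a 5.2-fold lower number from compound 3 to compound 4 (0.71 log units; beyond the scatter), and the other two comparisons agree, with a 5.9-fold lower number from compound 1 to compound 4 (0.77 log units; beyond the scatter) and a 6.0-fold lower number from compound 2 to compound 4 (0.78 log units; beyond the scatter). Compound 4 is the only one of the four whose phenyl group carries no halogen, and its 4-methoxyphenyl adds the one hydrogen-bond acceptor that 2-chloro-4-fluorophenyl lacks. No supporting measurement explains the difference. The compounds shown leave open which part of 4-methoxyphenyl matters, and whether unsubstituted phenyl or 4-ethoxyphenyl would keep the lower number.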